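The source may report more compounds than this note shows. Statements on the series, on what has been measured and on what is new or still open speak of the compounds shown alone.

Compound 1 `COc1ccc(-c2nc(CNC(=O)CSC)sc2-c2ccc(OC)cc2)cc1` carries on its core a ((((methylsulfanyl)methyl)carbonyl)amino)methyl group. In a functional assay with Oryctolagus cuniculus as the target (a higher number here means a weaker inhibitor, a lower number a stronger inhibitor), compound 1 reports only a limit, < 100 nM. Its standing rests on (the limit of < 100 nM in this assay, at which 2 of the 3 values shown sit), so no number separates it from compound 3 `CCOC(=O)C1=C(C)N=C(C)/C(=C(/O)OCC)C1c1nc(-c2ccc(OC)cc2)c(-c2ccc(OC)cc2)s1`, which in this assay also reaches a limit, < 100 nM. Compound 2 `COc1ccc(-c2nc(C(=O)N3CCNC(CCO)C3)sc2-c2ccc(OC)cc2)cc1` gives in this assay a limit at the other end, > 1000 nM, as the limit of > 1000 nM in this assay, at which 1 of the 3 values shown sits, records. Compound 4 `COc1ccc(-c2nc(C3=CCN(C)CC3)sc2-c2ccc(OC)cc2)cc1` has not been measured; it differs from compound 1 by a group of 7 heavy atoms (6 carbon, 1 nitrogen; one six-membered non-aromatic ring with 1 hetero atom) in place of a group of 7 heavy atoms (4 carbon, 1 nitrogen, 1 oxygen, 1 sulfur; no ring), on an aromatic carbon. Going by the values given here, no measured step shows how this assay answers such a change at this carbon. Compound 4 is expected to weaken moderately, the step of an at least 3.0-fold higher number from compound 1 to compound 4 (0.47 log units; beyond the scatter) estimated beyond the scatter. Compound 4 is therefore estimated at 300 nM, between 50 nM and 2000 nM.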

Compound 4, half-maximal inhibitory concentration: < 10 nM
Compound 4 was reported as a limit (the forecaster's own chance of this, stated with the estimate: 40%); middle value at least 30-fold (1.47 log units) away from the limit.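

Compound 1 and compound 4 are both reported in this assay only as limits, so the step between them cannot be read. The compounds shown leave open how large that exchange on the aromatic carbon is, and in which direction it runs.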